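GIRK Activators: A Fluoropyridyl Variant of an Amide Series

The source may report more compounds than this note shows. Statements on the series, on what has been measured and on what is new or still open speak of the compounds shown alone.

Of the compounds shown here, two sharing a common core have been measured in an assay on HEK293 cells for activation of Kir3.1/Kir3.2 (Homo sapiens), read by thallium flux; on this read-out lower numbers stand for smaller maximal responses and higher numbers for larger maximal responses. Compound 1 `Cc1cc(NC(=S)Cn2nnc(-c3ccccc3)n2)n(C2CCCCC2)n1` gives 80% in this assay. Compound 2 `Cc1cc(NC(=O)Cn2nnc(-c3cccnc3)n2)n(C2CCCCC2)n1` gives 96% in this assay, the higher of the two numbers, and its gap to compound 1 lies beyond the usual scatter of repeated measurements. The two differ in more than one place, so no single step between them is given; only their two values are shown.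

Compound 3 `Cc1cc(NC(=O)Cn2nnc(-c3ccnc(F)c3)n2)n(C2CCCCC2)n1` has not yet been measured in this assay. It differs from compound 2 in one place, (2-fluoropyridin-4-yl in place of pyridin-3-yl on an aromatic carbon), with 2-fluoropyridin-4-yl in place of pyridin-3-yl on an aromatic carbon of the five-membered aromatic ring with four nitrogen atoms.

Given that compound 2 reaches 96% in this assay, a step from compound 2 to compound 3 of a number 8 percentage points lower from compound 2 to compound 3 (within the scatter) is expected, downward but within the scatter. Compound 3 is therefore estimated to give 88% in this assay, with a range from 68% to 105%.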

Compound 3, largest response reached (Emax), in percent of the reference or control that the assay uses: 95%
For compound 3 the middle estimate is 7 percentage points below the measured one; the measured number falls inside the stated range.
By their numbers in this assay, from the lowest: compound 1; then compounds 3 and 2 (each within the scatter of the next).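

In this assay, putting 2-fluoropyridin-4-yl in place of pyridin-3-yl on the aromatic carbon of the five-membered aromatic ring with four nitrogen atoms gives a number 1 percentage points lower from compound 2 to compound 3 (within the scatter). Among the compounds shown here, this is the first comparison here that isolates a single place, and it shows that, on this read-out, the two groups at this position cannot be told apart, although the entering group carries a fluorine and is joined to the ring through a different ring carbon. Nothing available here accounts for this outcome.

The fluorine and the change of attachment arrive together in this one step, so the share of each remains unresolved, and a pyridin-4-yl group without fluorine would be needed to separate them. Going by these compounds, it also remains open how far this position accommodates other groups on the same pyridine ring, such as a 2-chloropyridin-4-yl, a 2-methoxypyridin-4-yl or a 2-aminopyridin-4-yl group, and whether maximal response would stay within the scatter of compound 2 with any of them.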